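The source may report more compounds than this note shows. Statements on the series, on what has been measured and on what is new or still open speak of the compounds shown alone.

The measured compounds and their values:

Compound 1, `Fc1ccc(-c2nn(-c3ccccc3)cc2-c2nc3ccccc3[nH]2)cc1`, gives 1510 nM in a functional assay on A549 cells (Homo sapiens) for antiproliferative activity, read by MTT assay, with a stated time of 48 h; a higher number here means a weaker inhibitor, a lower number a stronger inhibitor.
Compound 2, `Cc1ccc2[nH]c(-c3cn(-c4ccccc4)nc3-c3ccc(F)cc3)nc2c1`, gives 1440 nM in this assay.
Compound 3, `Cc1ccc2[nH]c(-c3cn(-c4ccccc4)nc3-c3ccc(Cl)cc3)nc2c1`, gives 4640 nM in this assay.

Compound 1 and compound 2 differ by methyl in place of hydrogen on an aromatic carbon, and the step is a 1.0-fold lower number from compound 1 to compound 2 (0.02 log units; within the scatter). Compound 2 and compound 3 differ by a chloro in place of fluoro on an aromatic carbon, and here the step is a 3.2-fold higher number from compound 2 to compound 3 (0.51 log units; beyond the scatter). For the measured compounds named here, the difference between the cores of compound 1 and compound 3 is not broken down here; their values show only that compound 3 sits at the weaker end of the three.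

Compound 4, `Cc1cc2nc(-c3cn(-c4ccccc4)nc3-c3ccc(Cl)cc3)[nH]c2cc1C`, has not yet been measured. It differs from compound 3 by methyl in place of hydrogen on an aromatic carbon. This is the same kind of change as that from compound 1 to compound 2, not the same: in compound 4 the entering methyl sits ortho to a methyl group (1 heavy atom), meta to a fused ring and para to a fused ring, whereas in compound 2 the place is only meta to a fused ring and para to a fused ring. Since the earlier step was within the scatter, the step from compound 3 to compound 4 is expected to be a 1.1-fold lower number from compound 3 to compound 4 (0.04 log units; within the scatter), resting on compound 3 at 4640 nM and the earlier step of a 1.0-fold lower number from compound 1 to compound 2 (0.02 log units; within the scatter). Compound 4 is therefore expected to give about 4200 nM, estimated between 1800 nM and 9500 nM.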

Compound 4, half-maximal inhibitory concentration: 17700 nM
For compound 4 the middle estimate is 4.2-fold (0.62 log units) below the measured one; measured number above the stated range.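

In this assay, methyl in place of hydrogen on an aromatic carbon gave a 3.8-fold higher number from compound 3 to compound 4 (0.58 log units; beyond the scatter), so on this core the change moved the number clearly towards a weaker inhibitor. Set beside the earlier step, the result shows that the effect of this change did not carry over from one core to the other in this series: the same change on two cores in this assay, a 1.0-fold lower number (0.02 log units; within the scatter) from compound 1 to compound 2 and a 3.8-fold higher number (0.58 log units; beyond the scatter) from compound 3 to compound 4, 4.0-fold (0.60 log units) apart, beyond the scatter of two such steps This does not show what separates the two steps, since each rests on a single pair of compounds, and the pairs differ both in the halogen, fluoro in compound 2 and chloro in compound 3, and in the place of the entering methyl, which in compound 4 alone stands ortho to a methyl group.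

The compounds shown leave open whether the second methyl would give a similar step with fluoro in place of chloro, and whether a single methyl would do so with chloro on the core of compound 1. They also leave open how other groups at the same aromatic carbon, such as a methoxy group, an amine or a carboxylic acid, would compare with methyl.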